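The source may report more compounds than this note shows. Statements on the series, on what has been measured and on what is new or still open speak of the compounds shown alone.

In an assay on isolated protein for inhibition of histone deacetylase 8 (Homo sapiens), read by chemiluminescence, with a stated time of 3 h (a lower number here means a stronger inhibitor, a higher number a weaker inhibitor), compound 2 `O=C(CCCCCCNC(=O)C(O)(O)C(F)(F)F)Nc1ncc(-c2ccc(Br)cc2)s1` gives 10000 nM. Compound 1 `COc1ccc(-c2cnc(NC(=O)CCCCCCNC(=O)C(O)(O)C(F)(F)F)s2)cc1` gives 13000 nM, and compound 3 `O=C(CCCCCCNC(=O)C(O)(O)C(F)(F)F)Nc1ccc(Br)cc1` gives 11000 nM; compound 2 has the lowest of the three numbers, but all three sit within the usual scatter of one another. Among the measured compounds shown here, the one measured step, a 1.3-fold lower number from compound 1 to compound 2 (0.11 log units; within the scatter), swaps one group on the outer ring for another and changes little. Compound 4 `O=C(CCCCCCNC(=O)C(O)(O)C(F)(F)F)Nc1ncc(-c2ccccc2)s1` differs from compound 2 by hydrogen in place of bromo on an aromatic carbon. Since compound 1 and compound 2 show that exchanging the group on that ring barely moves the number, the step of a 1.2-fold higher number from compound 2 to compound 4 (0.08 log units; within the scatter) is expected to stay within the scatter. Compound 4 is therefore estimated at 12000 nM, with a range from 6000 nM to 25000 nM.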

Compound 4, half-maximal inhibitory concentration: 21000 nM
The estimate for compound 4 lay 1.8-fold (0.24 log units) below the measured number, within the range that was stated.
By their numbers in this assay, from the lowest: compounds 2, 3, 1 and 4 (each within the scatter of the next, the first and the last beyond it).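

In this assay, among the compounds shown here, the loss of the bromo gives a 2.1-fold higher number from compound 2 to compound 4 (0.32 log units; beyond the scatter) and so is the first step at this position to pass beyond the scatter, though only modestly. Hydrogen in place of methoxy gives a 1.6-fold higher number from compound 1 to compound 4 (0.21 log units; within the scatter) and stays within the scatter, so these two groups cannot be told apart here. Nothing shown explains either step. Still open, going by these compounds, is how a chloro or methyl group at the same place, para to a large group, would read, and whether an amine or a carboxylic acid there would move the number further.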